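The source may hold more compounds than are shown below. What is called first, only, known or untested is meant among the compounds shown, and "the series" means these compounds.

Working notes on the series. Compound 1 `O=C1c2c[n+]([O-])c3ccccc3c2C(=O)c2c1c1ccccc1n2CCCCN1CCNCC1` gives 540 nM in a functional assay on A549 cells (Homo sapiens) for cytotoxicity, read by MTT assay, with a stated time of 72 h; on this read-out higher numbers stand for weaker inhibition and lower numbers for stronger inhibition. Compound 2 `CN(C)CCCCCn1c2c(c3ccccc31)C(=O)c1c[n+]([O-])c3ccccc3c1C2=O` gives 210 nM in this assay, and compound 3 `O=C1c2c[n+]([O-])c3ccccc3c2C(=O)c2c1c1ccccc1n2CCCN1CCC(O)CC1` gives 350 nM in this assay. Among these three numbers compound 3 stands second highest: its nearest neighbour is compound 1 a 1.5-fold lower number from compound 1 to compound 3 (0.19 log units; within the scatter), and the other step is a 1.7-fold higher number from compound 2 to compound 3 (0.22 log units; within the scatter), both within the scatter. Going by the values given here, the one step beyond the scatter so far is a 2.6-fold lower number from compound 1 to compound 2 (0.41 log units; beyond the scatter), a modest one.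

Compound 4 `O=C1c2c[n+]([O-])c3ccccc3c2C(=O)c2c1c1ccccc1n2CCN1CCCCC1` is not yet measured. It differs from compound 3 by piperidin-1-yl in place of (4-hydroxypiperidin-1-yl)methyl on a saturated chain carbon, two bonds along the chain from an aromatic nitrogen. All three measured steps concern a change of the end group and its chain, as this one does, and they ranged from within the scatter to modest. The change from compound 3 to compound 4 is therefore expected to give at most a small step in this assay, with no direction that the data can fix, estimated as a 1.1-fold higher number from compound 3 to compound 4 (0.06 log units; within the scatter). Compound 4 is expected to give about 400 nM in this assay, within a range of 180 nM to 900 nM.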

Compound 4, half-maximal inhibitory concentration: 1080 nM
The estimate for compound 4 lay 2.7-fold (0.43 log units) below the measured number, outside the stated range (above it).
By their numbers in this assay, from the lowest: compounds 2, 3, 1 and 4 (each within the scatter of the next, the first and the last beyond it).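

In this assay, replacing the 3-(4-hydroxypiperidin-1-yl)propyl chain with 2-(piperidin-1-yl)ethyl gives the first step from compound 3 that lies beyond the scatter, a 3.1-fold higher number from compound 3 to compound 4 (0.49 log units; beyond the scatter). Going by these compounds alone, the distance to the dimethylamino compound is the largest so far, a 5.1-fold higher number from compound 2 to compound 4 (0.71 log units; beyond the scatter), while the piperazine compound remains within the scatter, a 2.0-fold higher number from compound 1 to compound 4 (0.30 log units; within the scatter). Thus, a change of end group and chain at this place can shift the number beyond the scatter, although nothing available explains this shift.

The step from compound 3 to compound 4 combines the chain change with the change of end group, so the compounds shown do not separate the two. A 3-(piperidin-1-yl)propyl chain and a 2-(4-hydroxypiperidin-1-yl)ethyl chain would each isolate one of these changes.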